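Changing the Amide Tail of Compound 1 to a Carbamate

This account rests on a few compounds, and the source may have more. Where it says the series, first, only, none or still open, it means among the compounds named here.

Measured compounds in an assay on LtK cells with ATP-sensitive inward rectifier potassium channel 11 (Homo sapiens) as the target; a higher number here means that more compound is needed for the effect, a lower number that less compound is needed:
- compound 1 `CCC(=O)Nc1c(C(O)(C(F)(F)F)C(F)(F)F)ccc2ccccc12` gives 15 nM
- compound 2 `CCCC(=O)Nc1c(C(O)(C(F)(F)F)C(F)(F)F)ccc2ccccc12` gives 131 nM
- compound 3 `O=C(CCc1ccccc1)Nc1c(C(O)(C(F)(F)F)C(F)(F)F)ccc2ccccc12` gives 1750 nM

Compound 1 has the lowest number of the three. Its nearest neighbour is compound 2, reached by an 8.7-fold higher number from compound 1 to compound 2 (0.94 log units; beyond the scatter), and its furthest is compound 3, reached by a 120-fold higher number from compound 1 to compound 3 (2.07 log units; beyond the scatter). Between the two larger tails the gap is a 13-fold higher number from compound 2 to compound 3 (1.13 log units; beyond the scatter). All three compounds share the same core; they differ only in the group attached to the carbonyl carbon of the amide.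

Compound 4 `CC(C)OC(=O)Nc1c(C(O)(C(F)(F)F)C(F)(F)F)ccc2ccccc12` has not yet been measured. It differs from compound 1 by isopropoxy in place of ethyl on a carbonyl carbon. Among the compounds with values here, no measured step swaps an ethyl for an isopropoxy, so this pair cannot be read directly from the table. What the measured steps do show is that every enlargement of the tail beyond ethyl raised the number in this assay, modestly for compound 2 and strongly for compound 3. The isopropoxy group is a little larger than ethyl, so a modestly higher number is expected for compound 4 rather than none. For compound 4 the expected result is 40 nM, within a range of 10 nM to 160 nM, which corresponds to an estimated step of a 2.7-fold higher number from compound 1 to compound 4 (0.43 log units; beyond the scatter).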

Compound 4, half-maximal effective concentration: 1160 nM
Compound 4: middle estimate off by 29-fold (1.46 log units), on the low side; measured number outside the range, above it.
By their numbers in this assay, from the lowest: compound 1; then compound 2; then compounds 4 and 3 (each within the scatter of the next).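

Replacing the ethyl on the carbonyl carbon with isopropoxy, which turns the amide of compound 1 into a carbamate, has a large effect in this assay (a 77-fold higher number from compound 1 to compound 4 (1.89 log units; beyond the scatter)), and replacing the propyl of compound 2 with isopropoxy also carries a clear cost (an 8.9-fold higher number from compound 2 to compound 4 (0.95 log units; beyond the scatter)). Compound 4 and compound 3 cannot be told apart (a 1.5-fold lower number from compound 3 to compound 4 (0.18 log units; within the scatter)), even though the phenethyl tail of compound 3 is the bulkier one, so compound 4 goes against the earlier picture in which the number simply climbed with the size of the tail. Nothing available here explains why this change matters so much.

Going by these compounds, what remains open is whether the rise belongs to the oxygen now attached to the carbonyl carbon or to the branched isopropyl end of the new group. An ethoxy group on the same carbonyl carbon would keep the oxygen without the branch, and an isopropyl group would keep the branch without the oxygen, so this pair could begin to separate the two.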